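Benzyloxycarbonyl in place of pentylcarbonyl on the ring amide nitrogen

The source may hold more compounds than are shown below. What is called first, only, known or untested is meant among the compounds shown, and "the series" means these compounds.

Measured so far:
compound 1 `CCCN(CCC)c1nc(N2CCN(C(=O)c3ccco3)[C@@H]3CCCC[C@@H]32)nc2cc(OC)c(OC)cc12` — 0.0631 nM
compound 2 `CCCCCC(=O)N1CCN(c2nc(N)c3cc(OC)c(OC)cc3n2)[C@@H]2CCCC[C@@H]21` — 3.72 nM

In an assay on CHO cells for displacement of a labelled ligand from Alpha-1D adrenergic receptor (Homo sapiens), with a stated time of 30 min (a lower number here means a stronger inhibitor, a higher number a weaker inhibitor), compound 1 gives 0.0631 nM. In this assay compound 2 gives 3.72 nM, the higher of the two numbers shown, with compound 1 the only neighbour and its lower number lying well beyond the usual scatter. Among the measured compounds shown here, no change in a single place connects the two compounds, so no counted step is available; the two values only show that compound 2 sits at the weaker end of what has been measured.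

Compound 3 `COc1cc2nc(N3CCN(C(=O)OCc4ccccc4)[C@H]4CCCC[C@H]43)nc(N)c2cc1OC` is the next member to be measured. It differs from compound 2 by benzyloxy in place of pentyl on a carbonyl carbon. For the measured compounds named here, the acyl group on the ring amide nitrogen is the only thing that changes; the shared core and the amino group stay as in compound 2.

With no measured step of this kind in the series, the change from pentylcarbonyl to benzyloxycarbonyl is expected to move the number little, and the step of a 1.2-fold lower number from compound 2 to compound 3 (0.09 log units; within the scatter) is estimated to stay within or only just beyond the scatter. Compound 3 is accordingly expected to give about 3 nM, with a range from 0.8 nM to 12 nM.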

Compound 3, inhibition constant: 3.98 nM
The estimate for compound 3 lay 1.3-fold (0.12 log units) below the measured number; low and high end bracket the measured number.
By their numbers in this assay, from the lowest: compound 1; then compounds 2 and 3 (each within the scatter of the next).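

In this assay, among the compounds shown here, the exchange of pentylcarbonyl for benzyloxycarbonyl on the ring amide nitrogen gives a 1.1-fold higher number from compound 2 to compound 3 (0.03 log units; within the scatter) and provides the first single-place reading. At this position, the 5-carbon pentyl and the benzyloxy, with 8 heavy atoms, a six-membered aromatic ring and one hydrogen-bond acceptor, cannot be told apart by this measurement, so neither the added ring nor the added oxygen shows a readable effect when the two are introduced together with the shared core and amino group held constant. No measurement available here bears on why the two groups read alike.

For the compounds shown here, the single pair cannot separate the contributions of the oxygen and the aromatic ring, and it leaves open whether the same reading would hold for a chain longer than pentyl or for an acyl group carrying an amine or a carboxylic acid. Also open, from the compounds shown here alone, is whether benzyloxycarbonyl would read the same on the core of compound 1, which carries dipropylamino in place of the amino group.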